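Working notes: piperidin-1-yl in place of phenyl

The source may hold more compounds than are shown below. What is called first, only, known or untested is meant among the compounds shown, and "the series" means these compounds.

Three compounds of the series have been run in an ADME assay on Vero cells (Chlorocebus sabaeus) for cytotoxicity, read by resazurin assay, with a stated time of 72 h; a lower number here means that less compound is tolerated, a higher number that more compound is tolerated. Compound 1 `Cc1cccc(C(=O)/C=C/c2ccc([N+](=O)[O-])o2)c1` gives 55100 nM in this assay. For compound 2 `CC(C)(C)c1ccc(C(=O)/C=C/c2ccc([N+](=O)[O-])o2)cc1` the assay reports only a limit, > 100000 nM. For compound 3 `O=C(/C=C/c1ccc([N+](=O)[O-])o1)c1ccc(-c2ccccc2)cc1` the assay likewise reports only a limit, > 100000 nM. Compound 3 thus sits at the upper edge of the numbers shown, and one further value sits at the same edge. The step that the two limits leave unreadable from compound 2 to compound 3 cannot be read, because the limit of > 100000 nM in this assay, at which 2 of the 3 values shown sit, holds both of its ends.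

Compound 4 `O=C(/C=C/c1ccc([N+](=O)[O-])o1)c1ccc(N2CCCCC2)cc1` differs from compound 3 by piperidin-1-yl in place of phenyl on an aromatic carbon. For the measured compounds named here, no measured step follows a change of this kind, and the only step that ends at compound 3 is of unreadable size, so nothing argues for a move in either direction. The step of a number no higher from compound 3 to compound 4 (the limit leaves the size open) is therefore expected to stay within the scatter. Compound 4 is estimated at 100000 nM, with a range from 30000 nM to 300000 nM, and a further limit rather than a number is about as likely as not.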

Compound 4, half-maximal cytotoxic concentration: 349000 nM
Beside the measured number, compound 4's estimate is 3.5-fold (0.54 log units) below it; the whole stated range lies below it.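

The steps from compound 2 and from compound 3 to compound 4 cannot be read, because each starts from a limit and not from a number: the limit of > 100000 nM in this assay, at which 2 of the 4 values shown sit.

The compounds shown leave open whether piperidin-1-yl in place of phenyl or of tert-butyl changes the value in this assay at all, and by how much.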